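The compounds below may be only part of what the source reports. "The series", "measured", "known", "first", "only" and "open" are said of these compounds alone.

Compound 1, with the structure `Cc1ccnc(/C(N)=N/NC(=S)N2CCSCC2)c1`, reaches 62.5% in a functional assay on MCF7 cells (Homo sapiens) for cytotoxicity, read by MTT assay, with a stated time of 72 h, tested at 10 uM; a lower number here means less inhibition of growth, a higher number more inhibition of growth at the concentration tested. Compound 2, with the structure `N/C(=N\NC(=S)N1CCSCC1)c1ccccn1`, shares that core and gives 54.3% in this assay. The change between them is hydrogen in place of methyl on an aromatic carbon, and the step it made is a number 8.2 percentage points lower from compound 1 to compound 2 (within the scatter).

Compound 3, with the structure `Cc1cccc(/C(N)=N/NC(=S)N2CCCC2)n1`, gives 38.2% in this assay, the lowest of the three numbers; the difference between its core and the core of compound 1 is not broken down here.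

Compound 4, with the structure `N/C(=N\NC(=S)N1CCCC1)c1ccccn1`, has not yet been measured. It stands to compound 3 as compound 2 stands to compound 1: the change is hydrogen in place of methyl on an aromatic carbon. It is the same kind of change, not the same: around the place, the methyl of compound 1 sits opposite the ring nitrogen, while that of compound 3 sits next to the ring nitrogen.

Resting on a number 8.2 percentage points lower from compound 1 to compound 2 (within the scatter), the step from compound 3 to compound 4 is expected to be small, about a number 6.2 percentage points lower from compound 3 to compound 4 (within the scatter) in this assay. Compound 4 is therefore estimated at 32%, between 18% and 46%.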

Compound 4, percent growth inhibition at one concentration: 51.7%
Compound 4: the middle estimate sits 19.7 percentage points below what was measured; measured number outside the range, above it.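

In this assay, hydrogen in place of methyl on an aromatic carbon did not carry over as one fixed step between the two cores: the same change on two cores in this assay, a number 8.2 percentage points lower (within the scatter) from compound 1 to compound 2 and a number 13.5 percentage points higher (beyond the scatter) from compound 3 to compound 4, 21.7 percentage points apart, beyond the scatter of two such steps. Among these compounds, the new step is a number 13.5 percentage points higher from compound 3 to compound 4 (beyond the scatter), while pyrrolidin-1-yl in place of thiomorpholin-4-yl, with no methyl on either compound, gives a number 2.6 percentage points lower from compound 2 to compound 4 (within the scatter), so compound 2 and compound 4 stand within the scatter of each other. This shows that a step read on one core could not be applied to the other here, but it does not show why: the methyl of compound 3 stands next to the ring nitrogen and that of compound 1 does not, the group on the thiocarbonyl carbon differs as well, and a single pair on each core cannot separate these.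

The compounds shown leave open how a methyl placed elsewhere on the ring would behave on each core. They also leave open what a chlorine atom, a methoxy group or a longer chain such as ethyl would do in place of the methyl.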